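Growth-inhibition notes on a piperazinylquinoline isatin series

The compounds below may be only part of what the source reports. "The series", "measured", "known", "first", "only" and "open" are said of these compounds alone.

Measured compounds in an ADME assay on 184B5 cells (Homo sapiens) for cytotoxicity, read by sulforhodamine B assay, with a stated time of 48 h; a higher number here means a weaker inhibitor of growth, a lower number a stronger inhibitor of growth:

- compound 1 `O=C1C(=O)N(CN2CCN(c3ccnc4cc(Cl)ccc34)CC2)c2cccc(Br)c21`: 49000 nM
- compound 2 `O=C1C(=O)N(CN2CCN(c3ccnc4cc(Cl)ccc34)CC2)c2ccccc21`: 71700 nM
- compound 3 `O=C1C(=O)N(CN2CCN(c3ccnc4cc(C(F)(F)F)ccc34)CC2)c2cc(Br)ccc21`: 21800 nM

Compound 3 carries a trifluoromethyl on its quinoline part where compound 1 and compound 2 carry chloro, and its bromo sits elsewhere on the fused ring; the difference between the two cores is not broken down here. In this assay compound 3 gives the lowest of the three numbers, with compound 1 the nearest and compound 2 the furthest, both gaps beyond the scatter.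

Within the chloro pair the single change is hydrogen in place of bromo on an aromatic carbon, and the step it made was a 1.5-fold higher number from compound 1 to compound 2 (0.17 log units; within the scatter), so the bromo at that place adds little.

Compound 4 `O=C1C(=O)N(CN2CCN(c3ccnc4cc(C(F)(F)F)ccc34)CC2)c2ccccc21` is not yet measured. It differs from compound 3 by hydrogen in place of bromo on an aromatic carbon. This is the same kind of change as in the chloro pair, but not the same: in the chloro pair the bromo leaves a position ortho to a fused ring and meta to a fused ring, here it leaves a position meta to a fused ring and para to a fused ring.

The expected step is a 1.4-fold higher number from compound 3 to compound 4 (0.15 log units; within the scatter), placed next to the earlier one because the measured step was a 1.5-fold higher number from compound 1 to compound 2 (0.17 log units; within the scatter). Compound 4 is thus expected to give about 31000 nM, estimated between 15000 nM and 65000 nM.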

Compound 4, concentration for 50% growth inhibition: 43900 nM
Compound 4: middle estimate off by 1.4-fold (0.15 log units), on the low side, and the stated range covers the measured number.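

Hydrogen in place of bromo on an aromatic carbon gives a 2.0-fold higher number from compound 3 to compound 4 (0.30 log units; within the scatter), and in this assay this step and the earlier step on the chloro core do not differ: the same change on two cores in this assay, a 1.5-fold higher number (0.17 log units; within the scatter) from compound 1 to compound 2 and a 2.0-fold higher number (0.30 log units; within the scatter) from compound 3 to compound 4, 1.4-fold (0.14 log units) apart, within the scatter of two such steps

On these two cores, then, the change carries over as a small step that stays within the scatter each time, and the measured pairs offer no sign that the core alters it. Among the compounds shown here, this does not show that the bromo contributes to growth inhibition on either core, and with only two pairs, each losing its bromo from a different place on the fused system, the effect of the core cannot be separated from that of the place.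

On these data alone, the quinoline change has a single pair, where trifluoromethyl in place of chloro on an aromatic carbon gives a 1.6-fold lower number from compound 2 to compound 4 (0.21 log units; within the scatter), so it remains open whether that exchange would give the same small step on a core that keeps its bromo. Also open, as far as these compounds go, is whether another group at the bromo's place, such as a nitrile, an amine or a carboxylic acid, would move the number beyond the scatter on either core.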